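The source may hold more compounds than are shown below. What is called first, only, known or untested is meant among the compounds shown, and "the series" means these compounds.

Compound 3 `Cc1nc(-c2cccnc2)sc1-c1nnc(-c2ccccc2Cl)o1` was tested in an ADME assay on PANC-1 cells (Homo sapiens) for cytotoxicity, read by MTT assay; a lower number here means that less compound is tolerated, a higher number that more compound is tolerated. In this assay compound 3 gives > 100 ug/mL, which is a limit of the assay and not a number. Two related compounds share the same core. Compound 1 `Cc1nc(-c2cccnc2)sc1-c1nnc(Cc2ccccc2)o1` carries a benzyl group where compound 3 carries a 2-chlorophenyl group, and in this assay compound 1 gives > 100 ug/mL, again a limit. Compound 2 `Cc1nc(-c2cccnc2)sc1-c1nnc(-c2ccc(Br)cc2)o1` carries a 4-bromophenyl group in that place, and in this assay compound 2 gives > 100 ug/mL, also a limit. The steps a step that the two limits leave unreadable from compound 1 to compound 3 and a step that the two limits leave unreadable from compound 2 to compound 3, like a step that the two limits leave unreadable from compound 1 to compound 2, are therefore of unreadable size because of the limit of > 100 ug/mL in this assay, at which 3 of the 3 values shown sit.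

Compound 4 `COc1ccccc1-c1nnc(-c2sc(-c3cccnc3)nc2C)o1` differs from compound 3 in one place: methoxy in place of chloro on an aromatic carbon. Within the data shown here, no measured step exchanges only this group, and the three steps that swap the aryl piece all leave their size unread. The step that the limit leaves unreadable from compound 3 to compound 4 is thus expected to be one that cannot be told apart from the scatter. Compound 4 is therefore estimated at 150 ug/mL, within a range from 70 ug/mL to 400 ug/mL.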

Compound 4, half-maximal cytotoxic concentration: > 100 ug/mL
Compound 4 was reported as a limit; the forecaster's own chance of this, stated with the estimate: 80%; the middle value is on the limit's open side.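

In this assay compound 4 gives > 100 ug/mL, which is a limit and not a number. Its steps from compound 1, compound 2 and compound 3 cannot be read because all four compounds sit at one limit: the limit of > 100 ug/mL in this assay, at which 4 of the 4 values shown sit. The compounds shown leave open at what concentration any of them becomes cytotoxic, and whether the group exchanged on the shared core changes that concentration at all.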